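The source may hold more compounds than are shown below. What is called first, only, known or untested is meant among the compounds shown, and "the series" means these compounds.

Measured compounds and their maximal responses:

compound 1 `C=CCn1c(=O)n(C2CN(C(c3ccccc3)c3ccccc3)CC(CO)O2)c2nc(N)nc(O)c21`, in a functional assay on YAC-1 cells (Mus musculus) (a lower number here means a smaller maximal response, a higher number a larger maximal response), compound 1 gives 46%
compound 2 `Nc1nc(O)c2c(n1)n(C1OC(CO)[C@@H](O)[C@H]1O)c(=O)n2Cc1ccc(Cl)c(Cl)c1`, in this assay compound 2 gives 15%
compound 3 `C=CCn1c(=O)n([C@@H]2O[C@H](CO)[C@H]3OC(C)(CCC(=O)O)O[C@H]32)c2nc(N)nc(O)c21`, in this assay compound 3 gives 0%

Among these three numbers compound 2 stands second highest. Its nearest neighbour is compound 3, whose number lies lower by a gap beyond the usual scatter; its furthest is compound 1, whose number lies higher, again beyond the scatter. No two of the measured compounds differ in one place only, so no single-point step can be read from the numbers shown, and the three values can only be set side by side.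

The next compound to be measured is compound 4 `N#Cc1cccc(Cn2c(=O)n(C3OC(CO)[C@@H](O)[C@H]3O)c3nc(N)nc(O)c32)c1`. It differs from compound 2 as follows: 3-cyanophenyl in place of 3,4-dichlorophenyl on a saturated chain carbon bound to an aromatic nitrogen. The shared core, the sugar and the rest of the molecule are unchanged; only the group on the saturated chain carbon bound to an aromatic nitrogen is exchanged, 3,4-dichlorobenzyl for 3-cyanobenzyl.

Nothing in the measured set tests this exchange, so the size of the step is open. The working expectation is a step in this assay of no clear direction and not beyond the scatter, as estimated by no change at the digits printed from compound 2 to compound 4 (within the scatter). For compound 4 the estimated maximal response is 15%, with a range from 0% to 40%.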

Compound 4, largest response reached (reported as maximal response), in percent of the reference or control that the assay uses: 11%
The estimate for compound 4 lay 4 percentage points above the measured number; the measured number falls inside the stated range.
By their numbers in this assay, from the lowest: compound 3; then compounds 4 and 2 (each within the scatter of the next); then compound 1.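

First single-place step in the series: in this assay, exchanging 3,4-dichlorobenzyl for 3-cyanobenzyl on a saturated chain carbon bound to an aromatic nitrogen gives a number 4 percentage points lower from compound 2 to compound 4 (within the scatter), so at this position, the two chlorines and the nitrile read alike within the scatter for this one pair. The earlier compounds shown here differ from each other in more than one place and could not isolate this position; the new pair holds the sugar and the shared core constant and changes only the substituents on the phenyl ring of the benzyl group. No measurement available here accounts for the size of this step.

Still open, as far as these compounds go, is whether the same flat reading holds for other groups on this benzyl, such as an amine or a carboxylic acid on the phenyl ring, or for a longer chain such as phenethyl in place of benzyl. For the compounds shown here, also open is whether this exchange would read the same on the sugar-modified parents of compound 1 and compound 3, where no matching pair is available.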